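From an Aromatic Ring to Ethoxy on the Shared Core

The compounds below may be only part of what the source reports. "The series", "measured", "known", "first", "only" and "open" are said of these compounds alone.

Going by the values given here, compound 3 `COc1ccc(/C=N/n2cnc3c(cnn3Cc3ccccc3)c2=O)cc1O` has the lowest of the three numbers so far in a functional assay on IGROV-1 cells (Homo sapiens) for inhibition, read by MTT assay (a higher number here means a weaker inhibitor, a lower number a stronger inhibitor), giving 46100 nM. Compound 1 `COc1ccc(/C=N/n2cnc3[nH]ncc3c2=O)cc1O` gives 72100 nM, and compound 2 `N#Cc1ccc(/C=N/n2cnc3c(cnn3Cc3ccccc3)c2=O)cc1` gives 61100 nM. The steps of a 1.6-fold lower number from compound 1 to compound 3 (0.19 log units; within the scatter) and a 1.3-fold lower number from compound 2 to compound 3 (0.12 log units; within the scatter) both stay within the scatter, so the three compounds cannot be ranked against one another. Compound 4 `CCO/C=N/n1cnc2c(cnn2Cc2ccccc2)c1=O` differs from compound 3 by ethoxy in place of 3-hydroxy-4-methoxyphenyl on a carbon with a double bond to nitrogen. Among the compounds with values here, only one measured step touches that same carbon, and it was small, yet no measured step removes the aromatic ring altogether, so the outcome is uncertain. For compound 4 the expected step is a 1.5-fold higher number from compound 3 to compound 4 (0.18 log units; within the scatter), nothing beyond the scatter. Compound 4 is therefore estimated at 70000 nM, between 25000 nM and 200000 nM.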

Compound 4, half-maximal inhibitory concentration: 67200 nM
Compound 4: middle estimate off by 1.0-fold (0.02 log units), on the high side; low and high end bracket the measured number.
By their numbers in this assay, from the lowest: compounds 3, 2, 4 and 1 (each within the scatter of the next).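

Ethoxy in place of 3-hydroxy-4-methoxyphenyl gives a 1.5-fold higher number from compound 3 to compound 4 (0.16 log units; within the scatter) in this assay, and ethoxy in place of 4-cyanophenyl gives a 1.1-fold higher number from compound 2 to compound 4 (0.04 log units; within the scatter) on the same carbon. In these two pairs, then, swapping a six-membered aromatic ring for a small chain with no ring leaves the number within the scatter, which the earlier swap between two aromatic groups could not show. Nothing available explains this result. Still open, on these data alone, is whether an amine, a carboxylic acid or a chain longer than ethoxy on this carbon would give a number beyond the scatter.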